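The source may report more compounds than this note shows. Statements on the series, on what has been measured and on what is new or still open speak of the compounds shown alone.

Measured so far in a functional assay on K562 cells (Homo sapiens) for antiproliferative activity, read by MTT assay, with a stated time of 72 h; on this read-out higher numbers stand for weaker inhibition and lower numbers for stronger inhibition:
compound 1 `COc1ccc(-c2ncnn2-c2cc(OC)c(OC)c(OC)c2)cc1`: 950 nM
compound 2 `CCOc1ccc(-c2ncnn2-c2cc(OC)c(OC)c(OC)c2)cc1`: 20 nM
compound 3 `COc1ccccc1-c1ncnn1-c1cc(OC)c(OC)c(OC)c1`: a limit of the assay, > 10000 nM

Compound 1 and compound 2 differ by methyl in place of hydrogen on a saturated chain carbon bound to an oxygen on an aromatic ring; in this assay this gives a 48-fold lower number from compound 1 to compound 2 (1.68 log units; beyond the scatter). Compound 3 differs from compound 1 by 2-methoxyphenyl in place of 4-methoxyphenyl on an aromatic carbon, and the step is an at least 10-fold higher number from compound 1 to compound 3 (1.02 log units; beyond the scatter). For compound 3 the assay gives only a limit, (the limit of > 10000 nM in this assay, at which 1 of the 3 values shown sits). Compound 4 `CCOc1ccccc1-c1ncnn1-c1cc(OC)c(OC)c(OC)c1` has not been measured; it differs from compound 3 by methyl in place of hydrogen on a saturated chain carbon bound to an oxygen on an aromatic ring, the same change as from compound 1 to compound 2 at the same place. Resting on the measured step of a 48-fold lower number from compound 1 to compound 2 (1.68 log units; beyond the scatter), the expected step is an at least 5.0-fold lower number from compound 3 to compound 4 (0.69 log units; beyond the scatter), though the starting point is only a limit and the expectation is wide. Compound 4 is expected to give 2000 nM in this assay, between 200 nM and 10000 nM.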

Compound 4, half-maximal inhibitory concentration: > 10000 nM
Compound 4 gave a limit, no number; the forecaster's own chance of this, stated with the estimate: 30%; at least 5.0-fold (0.69 log units) between middle value and limit.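

In this assay compound 3 and compound 4 both give only a limit, so no step can be read between them: the limit of > 10000 nM in this assay, at which 2 of the 4 values shown sit.

Going by these compounds, whether methoxy to ethoxy changes the read-out at all from compound 3 to compound 4 stays open.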